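From 4-bromophenyl to 3-methoxyphenyl on the amide-type nitrogen

The source may report more compounds than this note shows. Statements on the series, on what has been measured and on what is new or still open speak of the compounds shown alone.

In a functional assay on HCT-116 cells (Homo sapiens) for inhibition, read by colorimetric assay, with a stated time of 3 days (a higher number here means a weaker inhibitor, a lower number a stronger inhibitor), compound 2 (`O=C(CCCCCCNC(=O)C(O)(O)C(F)(F)F)Nc1ccc(Br)cc1`) gives 3130 nM and compound 1 (`COc1ccc(NC(=O)CCCCCCNC(=O)C(O)(O)C(F)(F)F)cc1`) gives 4520 nM. Within the data shown here, these two values lie within the scatter of each other, so compound 2 stands level with the only other measured compound. Compound 3 (`COc1cccc(NC(=O)CCCCCCNC(=O)C(O)(O)C(F)(F)F)c1`) is the next to be considered, and it differs from compound 2 as follows: 3-methoxyphenyl in place of 4-bromophenyl on an amide-type nitrogen. In short, it has 3-methoxyphenyl in place of 4-bromophenyl on an amide-type nitrogen. Among the measured compounds shown here, one measured step bears on this change: a 1.4-fold lower number from compound 1 to compound 2 (0.16 log units; within the scatter), with bromo in place of methoxy on an aromatic carbon. For the measured compounds named here, no measured compound yet carries the 3-methoxyphenyl group, so that step is only a partial guide. A change beyond the scatter is therefore not expected, and the expected step is a 1.3-fold higher number from compound 2 to compound 3 (0.11 log units; within the scatter). Compound 3 is estimated at 4000 nM, within an expected range of 2000 nM to 8000 nM.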

Compound 3, half-maximal inhibitory concentration: 6110 nM
Compound 3: middle estimate off by 1.5-fold (0.18 log units), on the low side; low and high end bracket the measured number.
By their numbers in this assay, from the lowest: compounds 2, 1 and 3 (each within the scatter of the next).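

In this assay, two new comparisons bear on the group on the amide-type nitrogen: a 2.0-fold higher number from compound 2 to compound 3 (0.29 log units; within the scatter) with 3-methoxyphenyl in place of 4-bromophenyl, and a 1.4-fold higher number from compound 1 to compound 3 (0.13 log units; within the scatter) with 3-methoxyphenyl in place of 4-methoxyphenyl. The second comparison adds what the earlier pair could not show, a change from the 4-methoxyphenyl group to the 3-methoxyphenyl group, and that step too stays within the scatter, so none of the three steps among these aryl groups exceeds it. Nothing measured here offers an explanation for these numbers. The compounds shown leave open whether 3-bromophenyl would fit the same picture, and whether an amine or a carboxylic acid on the phenyl ring would give a step beyond the scatter. They also leave open what a longer chain in the shared core would do.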